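A Ring Swap at Constant Atom Count

The source may report more compounds than this note shows. Statements on the series, on what has been measured and on what is new or still open speak of the compounds shown alone.

Measured so far in a physicochemical assay for lipophilicity, measured as octanol-water partition, at pH 7.4; a higher number here means a more lipophilic compound, a lower number a more polar compound:
- compound 1 `Cc1ccc2[nH]c(C(=O)N[C@H]3CCN(S(=O)(=O)C4CC4)C[C@@H]3C(=O)NCCN(C)C)cc2c1` gives 1
- compound 2 `Cc1ccc2[nH]c(C(=O)N[C@H]3CN(S(=O)(=O)c4ccccc4)C[C@@H]3C(=O)NC[C@H]3CCCN3)cc2c1` gives 1

On these numbers, compound 2 stands level with compound 1, and the gap between them lies within the ordinary scatter of repeated measurements. The next compound to be measured, compound 3 `Cc1ccc2[nH]c(C(=O)N[C@H]3CN(S(=O)(=O)c4ccccc4)C[C@@H]3C(=O)N[C@H]3CCCNC3)cc2c1`, keeps all of compound 2 except for one piece: piperidin-3-yl in place of (pyrrolidin-2-yl)methyl on an amide-type nitrogen. The two compounds contain the same atoms, joined differently. Going by the values given here, no measured pair yet shows what this change does, so the expectation starts from compound 2 at 1 and carries a wide range. In this assay, no shift beyond the scatter is expected in either direction. The expected change is small, with the estimate reading a number 0.10 log units higher from compound 2 to compound 3 (within the scatter). For compound 3, the estimated value is 1.1, with a range from 0.6 to 1.6.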

Compound 3, distribution coefficient: 1.3
Estimate against measurement, compound 3: 0.20 log units below; the range from low to high includes it.
By their numbers in this assay, from the lowest: compounds 1, 2 and 3 (each within the scatter of the next).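

Placing piperidin-3-yl instead of (pyrrolidin-2-yl)methyl on the amide-type nitrogen gives the first step that can be read at this position: in this assay, the swap gives a number 0.30 log units higher from compound 2 to compound 3 (within the scatter). For this one pair, then, rejoining the same atoms from a five-membered non-aromatic ring into a six-membered one leaves the two compounds within the repeat scatter of each other. No measurement offers an explanation for this step. Going by these compounds alone, only one pair carries this change. From the compounds shown here alone, it remains open whether the same swap would give a similar step with a different group elsewhere in the molecule. Also open, going by these compounds, is what a ring without nitrogen, such as cyclohexyl, or a chain ending in a carboxylic acid would do on this amide-type nitrogen.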